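A few compounds are considered here, and "the series" means these few. Any claim that something is new, unique, unknown or untested is made for them only; others in the source may bear on it.

Working notes on the cytotoxicity counter-screen of the series.

Compound 1 `CN(C)c1cc2[nH]c(C3CCCCC3)nc2cc1NC(=O)c1ccc(OC(F)F)cc1` carries a 4-(difluoromethoxy)phenyl group on the carbonyl carbon; in an ADME assay on Vero cells (Chlorocebus sabaeus) for cytotoxicity, read by resazurin assay, with a stated time of 3 days (a higher number here means a weaker inhibitor, a lower number a stronger inhibitor), compound 1 returns only a limit, > 100 ug/mL. Compound 2 `CN(C)c1cc2[nH]c(C3CCCCC3)nc2cc1NC(=O)c1ccc(C(C)(C)C)cc1` bears a 4-(tert-butyl)phenyl group in the same position; in this assay compound 2 likewise returns a limit, > 100 ug/mL. Compound 3 `CN(C)c1cc2[nH]c(C3CCCCC3)nc2cc1NC(=O)c1cccc(Br)c1` holds a 3-bromophenyl group there; in this assay compound 3 also returns a limit, > 100 ug/mL. Compound 3 therefore stands at the same limit as the other two, and none of the three readings is a number. The steps a step that the two limits leave unreadable from compound 1 to compound 2, a step that the two limits leave unreadable from compound 1 to compound 3 and a step that the two limits leave unreadable from compound 2 to compound 3 cannot be sized because the limit of > 100 ug/mL in this assay, at which 3 of the 3 values shown sit, is where every value sits.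

Compound 4 `CN(C)c1cc2[nH]c(C3CCCCC3)nc2cc1NC(=O)c1ccc(F)cc1F` differs from compound 3 by 2,4-difluorophenyl in place of 3-bromophenyl on a carbonyl carbon. All three measured steps change the same aryl group on the carbonyl carbon, and all are unreadable, so no direction beyond the scatter can be drawn for this assay. The step from compound 3 to compound 4 is expected to be flat, about a number no higher from compound 3 to compound 4 (the limit leaves the size open), with the reading most likely staying at the limit. Compound 4 is estimated at 100 ug/mL, within 50 ug/mL to 200 ug/mL.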

Compound 4, half-maximal inhibitory concentration: > 100 ug/mL
Compound 4 was reported as a limit; the forecaster's own chance of this, stated with the estimate: 85%; the middle value sits exactly at the limit.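

No step from compound 1, compound 2 or compound 3 to compound 4 can be read, since all four compounds sit at one limit in this assay: the limit of > 100 ug/mL in this assay, at which 4 of the 4 values shown sit.

The compounds shown leave open whether any group on the carbonyl carbon gives a numerical reading in this assay.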